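The source may report more compounds than this note shows. Statements on the series, on what has been measured and on what is new or still open speak of the compounds shown alone.

Measured in an ADME assay on Vero cells (Chlorocebus sabaeus) for cytotoxicity, read by resazurin assay, with a stated time of 24 h; a higher number here means that more compound is tolerated, a lower number that less compound is tolerated:
- Compound 1 `CC(=O)OC[C@H]1O[C@H](OCCC(C)C)C=C([C@H](O)c2ccc([N+](=O)[O-])cc2)C1=O`: 14300 nM
- Compound 2 `Cc1ccc(S(=O)(=O)OC[C@H]2O[C@H](OC(C)C)C=CC2=O)cc1`: 13400 nM
- Compound 3 `CCCCCCO[C@@H]1C=CC(=O)[C@@H](COC(=O)C(C)(C)C)O1`: 4800 nM

Compound 3 has the lowest number of the three, and its gaps to compound 1 and compound 2 both lie beyond the scatter. Compound 4 `CC(C)O[C@@H]1C=CC(=O)[C@@H](COC(=O)C(C)(C)C)O1` differs from it by one change, (isopropyl in place of hexyl on an oxygen on a saturated carbon). Within the data shown here, no measured pair in this set differs in one place, so the expectation rests on thin evidence. Among the measured compounds shown here, the only measured compound with isopropyl, compound 2, gives 13400 nM, though it also differs elsewhere. A modest rise in the number is expected, with the estimated step being a 1.8-fold higher number from compound 3 to compound 4 (0.25 log units; within the scatter). For compound 4 the estimated value is 8500 nM, with an expected range of 4300 nM to 17000 nM.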

Compound 4, half-maximal cytotoxic concentration: 12500 nM
Estimate against measurement, compound 4: 1.5-fold (0.17 log units) below, within the range that was stated.
By their numbers in this assay, from the lowest: compound 3; then compounds 4, 2 and 1 (each within the scatter of the next).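

In this assay, the series gains its first pair differing in one place: a 2.6-fold higher number from compound 3 to compound 4 (0.42 log units; beyond the scatter), for isopropyl in place of hexyl on an oxygen on a saturated carbon. This shows that the group on this oxygen can, by itself, move the number beyond the scatter, which compounds 1 and 2 could not show. Nothing measured here accounts for the step.

Chain size and branching remain unseparated; a straight propyl or a longer octyl chain on this oxygen would help part them. As far as these compounds go, whether the step carries over to the other compounds' substitution is also open.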